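A Tosyl Ester on the Phenol of Compound 2

The compounds below may be only part of what the source reports. "The series", "measured", "known", "first", "only" and "open" are said of these compounds alone.

Of the compounds shown here, two of a shared core have been measured in a functional assay on A549 cells (Homo sapiens) for cytotoxicity, read by MTT assay, with a stated time of 4 days; on this read-out higher numbers stand for weaker inhibition and lower numbers for stronger inhibition. Compound 1 `C=C1C[C@]23C[C@@]1(O)CC[C@H]2c1ccc(OS(=O)(=O)c2ccc(C)cc2)c(C)c1[C@@H]3Cn1cc(-c2ccc(OC)cc2)nn1` carries a ((4-methylphenyl)sulfonyl)oxy group and a methoxyphenyl on its triazole; in this assay compound 1 gives only a limit, > 20000 nM. Among the compounds with values here, compound 2 `C=C1C[C@]23C[C@@]1(O)CC[C@H]2c1ccc(O)c(C)c1[C@@H]3Cn1cc(-c2ccc(C(F)(F)F)cc2)nn1` carries a free hydroxy and a trifluoromethylphenyl on its triazole; in this assay compound 2 gives 10400 nM, the one actual number among the two values. Compound 3 `C=C1C[C@]23C[C@@]1(O)CC[C@H]2c1ccc(OS(=O)(=O)c2ccc(C)cc2)c(C)c1[C@@H]3Cn1cc(-c2ccc(C(F)(F)F)cc2)nn1` differs from compound 2 by (4-methylphenyl)sulfonyl in place of hydrogen on an oxygen on an aromatic ring. Within the data shown here, no measured pair shares this change alone; compound 1, the one compound bearing the same sulfonyl ester, sits at the limit of > 20000 nM in this assay, at which 1 of the 2 values shown sits. Compound 3 is therefore expected to lose rather than gain, with a step of a 2.1-fold higher number from compound 2 to compound 3 (0.33 log units; beyond the scatter) beyond the scatter toward weaker inhibition. Compound 3 is estimated at 22000 nM, within 8000 nM to 60000 nM, with a fair chance that only a limit is returned.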

Compound 3, half-maximal inhibitory concentration: > 20000 nM
Compound 3 was reported as a limit; the forecaster's own chance of this, stated with the estimate: 55%; the middle value lies beyond the limit too.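

With the sulfonyl ester now measured on its own, replacing the hydrogen on the oxygen on an aromatic ring gives, in this assay, an at least 1.9-fold higher number from compound 2 to compound 3 (0.28 log units; that floor lies within the scatter). On these data alone, compound 3 gives > 20000 nM, which is a limit of the assay and not a number, so the true size of this step remains unknown. Compound 1 and compound 3, the two compounds bearing the ester, carry methoxy and trifluoromethyl respectively in the one place where they differ, yet the step between them cannot be read, and both sit at the same limit: the limit of > 20000 nM in this assay, at which 2 of the 3 values shown sit.

As far as these compounds go, how an acetate ester or a methyl ether on this oxygen would read in this assay stays open. So does whether a carboxylic acid in place of the trifluoromethyl would shift the number of compound 2.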